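The source may report more compounds than this note shows. Statements on the series, on what has been measured and on what is new or still open speak of the compounds shown alone.

Measured in a functional assay on Ramos cells (Homo sapiens) for cytotoxicity, with a stated time of 20 h; a higher number here means that more compound is tolerated, a lower number that less compound is tolerated:
compound 1 `O=C(COc1ccc2cc(/C=C3/SC(=O)NC3=O)ccc2c1)Nc1cccc(C(F)(F)F)c1`: 6200 nM
compound 2 `O=C(COc1ccc2cc(/C=C3/SC(=O)NC3=O)ccc2c1)Nc1c(F)cc(F)cc1Br`: 9600 nM

Going by the values given here, compound 2, at 9600 nM, lies within the scatter of compound 1, its only measured neighbour. Among the compounds with values here, the single measured step, a 1.5-fold higher number from compound 1 to compound 2 (0.19 log units; within the scatter), exchanged the group on an amide-type nitrogen and left the shared core untouched.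

Compound 3 `O=C(COc1ccc2cc(/C=C3/SC(=O)NC3=O)ccc2c1)Nc1cccc(Cl)c1` has not yet been measured. It carries 3-chlorophenyl in place of 2-bromo-4,6-difluorophenyl on an amide-type nitrogen. Within the data shown here, the one measured step bears directly on this change, as it concerns the same place and stayed within the scatter. Compound 1, with 3-(trifluoromethyl)phenyl there, gives 6200 nM. No change beyond the scatter is therefore expected in this assay. The expected step is a 1.5-fold lower number from compound 2 to compound 3 (0.17 log units; within the scatter). For compound 3 the estimated value is 6500 nM, with an expected range from 3000 nM to 14000 nM.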

Compound 3, half-maximal cytotoxic concentration: 9100 nM
Compound 3: middle estimate off by 1.4-fold (0.15 log units), on the low side, within the range that was stated.
By their numbers in this assay, from the lowest: compounds 1, 3 and 2 (each within the scatter of the next).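

A third aryl group on the amide-type nitrogen again stayed within the scatter in this assay and gave a 1.1-fold lower number from compound 2 to compound 3 (0.02 log units; within the scatter) even though the bromo and both fluoro substituents were gone. Chloro in place of trifluoromethyl on an aromatic carbon, a change confined to a single substituent, gave a 1.5-fold higher number from compound 1 to compound 3 (0.17 log units; within the scatter) and so also stayed within the scatter. Across the three aryl groups shown, this place has produced no step beyond the scatter, and nothing at hand bears on why.

On these data alone, all three groups on this nitrogen are halogen-bearing phenyl rings, so it stays open whether an amine or a carboxylic acid on that ring, or a longer alkyl chain in its place, would move the number beyond the scatter. Also open, as far as these compounds go, is whether a change to the shared core would do so.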